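Chain extension on an aromatic ether: notes on four compounds

A few compounds are considered here, and "the series" means these few. Any claim that something is new, unique, unknown or untested is made for them only; others in the source may bear on it.

Measured so far:
compound 1, `CCCCCCCCOc1cc(OC)c(Br)cc1C(C)=O` — in a functional assay, with a stated time of 30 min (a lower number here means a stronger inhibitor, a higher number a weaker inhibitor), compound 1 gives 39000000 nM
compound 2, `CCCCCCCCCCOc1cc(OC)c(Br)cc1C(C)=O` — in this assay compound 2 gives 35100000 nM
compound 3, `CCCCCCCCCCOc1cc(OC)ccc1C(C)=O` — in this assay compound 3 gives 40100000 nM

The change from compound 1 to compound 2 is ethyl in place of hydrogen on a saturated chain carbon, eight bonds along the chain from an oxygen on an aromatic ring; it gives a 1.1-fold lower number from compound 1 to compound 2 (0.05 log units; within the scatter). The step of a 1.1-fold higher number from compound 2 to compound 3 (0.06 log units; within the scatter) is likewise small. The difference between the cores of compound 1 and compound 3 is not broken down here.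

Compound 4, `CCCCCCCCCCCCOc1cc(OC)ccc1C(C)=O`, is not yet measured; it differs from compound 3 by ethyl in place of hydrogen on a saturated chain carbon, ten or more bonds along the chain from an oxygen on an aromatic ring. This is the same kind of change as that from compound 1 to compound 2, though the place along the chain differs, as the two descriptions of the change show. In this assay the step from compound 3 to compound 4 is expected to be a 1.1-fold lower number from compound 3 to compound 4 (0.02 log units; within the scatter), because the same kind of change gave a 1.1-fold lower number from compound 1 to compound 2 (0.05 log units; within the scatter). Compound 4 is therefore estimated at 38000000 nM, with a range from 22000000 nM to 65000000 nM.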

Compound 4, half-maximal inhibitory concentration: 37400000 nM
The estimate for compound 4 lay 1.0-fold (0.01 log units) above the measured number; the range from low to high includes it.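

In this assay, ethyl in place of hydrogen on a saturated chain carbon, ten or more bonds along the chain from an oxygen on an aromatic ring, gives a 1.1-fold lower number from compound 3 to compound 4 (0.03 log units; within the scatter). The change reads alike on the two cores: the same change on two cores in this assay, a 1.1-fold lower number (0.05 log units; within the scatter) from compound 1 to compound 2 and a 1.1-fold lower number (0.03 log units; within the scatter) from compound 3 to compound 4, 1.0-fold (0.02 log units) apart, within the scatter of two such steps. This shows that, on these two cores, the change carries over without a step beyond the scatter; it does not show that the change itself moves the number on either core, and two cores give no rule for the whole series.

Going by these compounds, whether a longer chain, or a chain carrying an amine or a carboxylic acid, would give a step beyond the scatter remains open. Also open, on these data alone, is how the same change reads on any core other than those of compound 1 and compound 3.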